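The compounds below may be only part of what the source reports. "The series", "measured", "known", "first", "only" and "open" are said of these compounds alone.

Compound 3 `O=C(Nc1cccnc1)c1ccc(Cl)cc1` gives the largest number shown in an assay on V79 cells for inhibition of cytochrome P450 11B1, mitochondrial (Homo sapiens), tested at 500 nM (on this read-out higher numbers stand for more inhibition at the one concentration tested (going by the name of the read-out) and lower numbers for less inhibition), namely 5%, though this says little on its own: compound 2 `O=C(Nc1cccnc1)c1ccccc1` gives 2% and compound 1 `O=C(Nc1cccnc1)c1cncc(Br)c1` gives 0.4%, and both gaps lie within the usual scatter. For the measured compounds named here, the single measured step, a number 3 percentage points higher from compound 2 to compound 3 (within the scatter), came from placing chloro where hydrogen had been and did not rise above the scatter either. Compound 4 `O=C(Nc1cccnc1)c1ccc(OC(F)(F)F)cc1` differs from compound 3 by trifluoromethoxy in place of chloro on an aromatic carbon. Going by the values given here, no measured step exchanges one group for another on that aromatic carbon, so the only guide is that nothing so far has moved this read-out noticeably, and no step beyond the scatter is expected in this assay. Compound 4 is therefore estimated at 4%, within 0% to 12%, an expected step of a number 1 percentage points lower from compound 3 to compound 4 (within the scatter).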

Compound 4, a percentage reported as inhibition, at one concentration (the size of the read-out at that concentration, not a potency): 3%
For compound 4 the middle estimate is 1 percentage points above the measured one; the measured number falls inside the stated range.
By their numbers in this assay, from the lowest: compounds 1, 2, 4 and 3 (each within the scatter of the next).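

In this assay, for the compounds shown here, the exchange of chloro for trifluoromethoxy on this aromatic carbon gives a number 2 percentage points lower from compound 3 to compound 4 (within the scatter) and is the first measured swap of one group for another at this place. Against hydrogen, trifluoromethoxy gives a number 1 percentage points higher from compound 2 to compound 4 (within the scatter) and so, like chloro, stays within the scatter of hydrogen. No measured finding here accounts for this flat result.

Still open, going by these compounds, is whether an amine, a carboxylic acid or a longer alkyl chain on this carbon would lift the number beyond the scatter.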